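The compounds below may be only part of what the source reports. "The series", "measured", "known", "first", "only" and "open" are said of these compounds alone.

Compound 1 `COc1ccc(S(C)(=O)=O)c(NCC2=NCCN2)c1` carries a methylsulfonyl group on its core. In a functional assay on CHO cells for agonist activity at Alpha-2C adrenergic receptor (Homo sapiens) (on this read-out higher numbers stand for larger maximal responses and lower numbers for smaller maximal responses), compound 1 gives 49%, the lowest of the two numbers recorded so far. For the measured compounds named here, its nearest neighbour is compound 2 `CS(=O)(=O)c1ccc(F)cc1NCC1=NCCN1`, which in this assay gives 91%; the single recorded step, fluoro in place of methoxy on an aromatic carbon, runs a number 42 percentage points higher from compound 1 to compound 2 (beyond the scatter).

Compound 3 `COc1ccc(SC)c(NCC2=NCCN2)c1` is not yet measured in this assay. It differs from compound 1 in one place: methylsulfanyl in place of methylsulfonyl on an aromatic carbon. Going by the values given here, none of the measured steps touches this group; the only step available, from compound 1 to compound 2, concerns the methoxy and not the methylsulfonyl, so it gives no direct guide to the size or direction of the present change. Among the compounds with values here, with no step on this group to lean on, the expectation for compound 3 is left close to compound 1 with a wide margin on either side, and the step is estimated as a number 6 percentage points higher from compound 1 to compound 3 (within the scatter). The estimate for compound 3 in this assay is 55%, expected to fall between 30% and 85%.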

Compound 3, largest response reached (reported as maximum), in percent of the reference or control that the assay uses: 74%
Compound 3: the middle estimate sits 19 percentage points below what was measured, and the stated range covers the measured number.
By their numbers in this assay, from the lowest: compound 1; then compound 3; then compound 2.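

In this assay the position carrying the methylsulfonyl group now has a step of its own, with the methoxy group unchanged: a number 25 percentage points higher from compound 1 to compound 3 (beyond the scatter) for methylsulfanyl in place of methylsulfonyl. For the compounds shown here, the earlier step concerned only the methoxy group, so this result is the first to show that the maximal response also depends on the group at this aromatic carbon, ortho to a group of 7 heavy atoms and para to the methoxy group. It also shows that, with this methoxy group in place, the two oxygen atoms of the methylsulfonyl group are not needed for a response of this size, although the data on hand give no reason for the change.

Going by these compounds alone, only two groups have been compared at this position, so it remains open how a methylsulfinyl group, a longer alkylsulfanyl chain or an amine would read there. As far as these compounds go, it is also open whether the methylsulfanyl step would keep its direction and size with fluoro in place of the methoxy group, and whether the two single changes would add up in one compound.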